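What happens when the 3,4-dichlorophenyl group goes?

The source may hold more compounds than are shown below. What is called first, only, known or untested is meant among the compounds shown, and "the series" means these compounds.

Of the compounds shown here, three sharing one core have been measured in a functional assay on cells (T-cell line, Homo sapiens) for inhibition; on this read-out lower numbers stand for stronger inhibition and higher numbers for weaker inhibition. There, compound 1 `COc1cccc(CCCN2CCC(COC(c3ccccc3)c3ccccc3)CC2)c1` gives 1500 nM, compound 2 `COc1ccccc1CCCN1CCC(COC(c2ccccc2)c2ccccc2)CC1` gives 2400 nM and compound 3 `Clc1ccc(CCCN2CCC(COC(c3ccccc3)c3ccccc3)CC2)cc1Cl` gives 2200 nM. Compound 3 therefore stands level with the other two, within the usual scatter of repeat measurements.

Compound 4 `CCCN1CCC(COC(c2ccccc2)c2ccccc2)CC1` alters the same place: hydrogen in place of 3,4-dichlorophenyl on a saturated chain carbon, three bonds along the chain from an amine nitrogen in a ring. In words, hydrogen replaces 3,4-dichlorophenyl, so the aromatic ring is lost.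

For the measured compounds named here, three measured steps bear on this place: a 1.6-fold higher number from compound 1 to compound 2 (0.20 log units; within the scatter), a 1.5-fold higher number from compound 1 to compound 3 (0.17 log units; within the scatter) and a 1.1-fold lower number from compound 2 to compound 3 (0.04 log units; within the scatter). All are small and within the scatter, so exchanging one ring for another has shown no measurable change. However, all three compounds keep a ring there, so none shows directly what losing it does.

The expected change is a 2.7-fold higher number from compound 3 to compound 4 (0.44 log units; beyond the scatter), towards a higher number and weaker inhibition, and this estimate is uncertain. For compound 4 the estimated value is 6000 nM, with an expected range from 2000 nM to 20000 nM.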

Compound 4, half-maximal inhibitory concentration: 17800 nM
Compound 4: the middle estimate sits 3.0-fold (0.47 log units) below what was measured, and the stated range covers the measured number.
By their numbers in this assay, from the lowest: compounds 1, 3 and 2 (each within the scatter of the next); then compound 4.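

The earlier compounds shown here only exchanged one aromatic ring for another, whereas removing the ring altogether has a clear cost in this assay: there is an 8.1-fold higher number from compound 3 to compound 4 (0.91 log units; beyond the scatter) and a 7.4-fold higher number from compound 2 to compound 4 (0.87 log units; beyond the scatter) and a 12-fold higher number from compound 1 to compound 4 (1.07 log units; beyond the scatter) with each step lying beyond the scatter. Across these four compounds, and with none going against it, a ring on the saturated chain carbon goes with stronger inhibition, while the three ring types shown cannot be told apart. No supporting measurement is available to explain this loss of inhibition.

On these data alone, what remains open is whether the ring must be aromatic or whether other carbon groups would serve as well, which a cyclohexyl ring or a longer chain such as pentyl at this place could test. It is also open how a pyridyl ring, with nitrogen in the ring, would compare with the rings shown.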